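The compounds below may be only part of what the source reports. "The series", "measured", "known", "first", "only" and "open" are said of these compounds alone.

Values in a functional assay on MIA PaCa-2 cells (Homo sapiens) for cytotoxicity, read by MTT assay, with a stated time of 4 h (a lower number here means a stronger inhibitor, a higher number a weaker inhibitor), so far:
Compound 1 `COC1=CC(=O)c2c(c(COc3ccccc3)c(C)n2C)C1=O` gives 1390 nM
Compound 2 `COC1=CC(=O)c2c(c(C(C)Oc3ccc([N+](=O)[O-])cc3)c(C)n2C)C1=O` gives 1830 nM
Compound 3 `COC1=CC(=O)c2c(COc3ccc(N)cc3)c(C)n(C)c2C1=O` gives 504 nM

Compound 3 holds the lowest number of the three, and compound 1 and compound 2 both lie higher by more than the scatter. The next compound to be read is compound 4 `COC1=CC(=O)c2c(COc3ccncc3)c(C)n(C)c2C1=O` with pyridin-4-yl in place of 4-aminophenyl on an oxygen on a saturated carbon as its change from compound 3. Going by the values given here, no two measured compounds differ in one place alone, so the series offers no measured step to scale this change against. The expectation in this assay is a moderate rise in the number, beyond the scatter but not a large one. Among the compounds with values here, it rests on compound 3 (at 504 nM) being the only measured compound with 4-aminophenyl, while compound 1 (at 1390 nM) and compound 2 (at 1830 nM) lack that group and both sit higher. The estimated step is a weakening (a 2.2-fold higher number from compound 3 to compound 4 (0.34 log units; beyond the scatter)) with wide uncertainty. For compound 4 the estimated value is 1100 nM with an expected range from 350 nM to 3300 nM and no narrower claim.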

Compound 4, half-maximal inhibitory concentration: 2560 nM
Estimate against measurement, compound 4: 2.3-fold (0.37 log units) below, and the stated range covers the measured number.
By their numbers in this assay, from the lowest: compound 3; then compounds 1, 2 and 4 (each within the scatter of the next).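

In this assay, going by these compounds alone, the step of a 5.1-fold higher number from compound 3 to compound 4 (0.71 log units; beyond the scatter) is the only one-place comparison, and it shows that the group on the oxygen on a saturated carbon can move the number beyond the scatter. The change replaces a carbon-only aromatic ring bearing a hydrogen-bond donor with a ring holding one hetero atom and no donor, and compound 4 gives 2560 nM. No measurement shown here links the step to either of these differences.

Compound 1 and compound 2 differ from compound 3 in more than one place, so steps to them cannot be read. Open, on these data alone, is whether the lower number of compound 3 would survive with an acetamide, a dimethylamino group or a hydroxyl in place of the amine on the phenyl ring.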